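A few compounds are considered here, and "the series" means these few. Any claim that something is new, unique, unknown or untested is made for them only; others in the source may bear on it.

Compound 1 `Cc1cc(=O)oc2cc(OCc3nnc(S)s3)ccc12` and compound 2 `Cc1c(C)c2ccc(OCc3nnc(S)s3)cc2oc1=O` share one core with a thiadiazole-thiol side chain. In a functional assay on the whole organism (strain Wistar) for inhibition, with Rattus norvegicus as the target, with a stated time of 4 h (a higher number here means that more compound is needed for the effect, a lower number that less compound is needed), compound 1 gives 7.95 nM, and compound 2 gives 9.55 nM. For the measured compounds named here, the only change between them is methyl in place of hydrogen on an aromatic carbon, which produced a 1.2-fold higher number from compound 1 to compound 2 (0.08 log units; within the scatter). Compound 3 `Cc1cc(=O)oc2cc(OCC(=O)NNC(=S)Nc3ccc(Cl)cc3)ccc12` carries a longer side chain ending in a chlorophenyl thiosemicarbazide; the difference between its core and that of compound 1 is not broken down here. In this assay compound 3 gives 41.4 nM, the highest of the three numbers. Compound 4 `Cc1c(C)c2ccc(OCC(=O)NNC(=S)Nc3ccc(Cl)cc3)cc2oc1=O` is not yet measured and differs from compound 3 by methyl in place of hydrogen on an aromatic carbon, the same change as that from compound 1 to compound 2. Because that earlier change gave a 1.2-fold higher number from compound 1 to compound 2 (0.08 log units; within the scatter) the expected step is a 1.2-fold higher number from compound 3 to compound 4 (0.08 log units; within the scatter). Compound 4 is therefore expected to give about 50 nM in this assay, most likely between 22 nM and 115 nM.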

Compound 4, concentration for half-maximal effect: 196 nM
Estimate against measurement, compound 4: 3.9-fold (0.59 log units) below; the whole stated range lies below it.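

In this assay, methyl in place of hydrogen on an aromatic carbon gave a 4.7-fold higher number from compound 3 to compound 4 (0.68 log units; beyond the scatter). Set beside the earlier step, the same change did not carry over at the same size from the compounds with the thiadiazole-thiol side chain to those with the chlorophenyl thiosemicarbazide side chain: the same change on two cores in this assay, a 1.2-fold higher number (0.08 log units; within the scatter) from compound 1 to compound 2 and a 4.7-fold higher number (0.68 log units; beyond the scatter) from compound 3 to compound 4, 3.9-fold (0.60 log units) apart, beyond the scatter of two such steps. So a step measured on one pair of compounds was a poor guide to the other pair here, but two pairs do not show why the steps differ or what would happen with other side chains.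

On these data alone, it remains open whether the larger step goes with the whole thiosemicarbazide chain or only with its chlorophenyl end. A matched pair carrying an unsubstituted phenyl at that end, or a carboxylic acid in its place, could help separate the two.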